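Thiazolo-fused series: meta-methoxy step on the aryl group

A few compounds are considered here, and "the series" means these few. Any claim that something is new, unique, unknown or untested is made for them only; others in the source may bear on it.

Measured compounds:
compound 1, `Cc1nc2sc(-c3ccccc3)nc2c(=O)[nH]1`, 11%
compound 2, `COc1cccc(-c2nc3c(=O)[nH]c(C)nc3s2)c1`, 1%
compound 3, `CCOc1nc(C)nc2sc(Nc3ccccc3)nc12`, 2%

Three compounds have been run in an assay on CHO cells for displacement of a labelled ligand from adenosine receptor A1 (Homo sapiens), read by scintillation counting, with a stated time of 120 min, tested at 1 uM; on this read-out lower numbers stand for less inhibition and higher numbers for more inhibition at the one concentration tested (going by the name of the read-out). Compound 1, `Cc1nc2sc(-c3ccccc3)nc2c(=O)[nH]1`, gives 11%. Compound 2, `COc1cccc(-c2nc3c(=O)[nH]c(C)nc3s2)c1`, gives 1%. Compound 3, `CCOc1nc(C)nc2sc(Nc3ccccc3)nc12`, gives 2%. All three read-outs sit close to one another, and none of the gaps between them is beyond the usual scatter of repeated measurements of this kind.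

Among the compounds with values here, the one change already measured is that from compound 1 to compound 2: methoxy in place of hydrogen on an aromatic carbon. This step came out as a number 10 percentage points lower from compound 1 to compound 2 (within the scatter), so within the scatter the methoxy group changed nothing that can be counted on.

Compound 4, `CCOc1nc(C)nc2sc(Nc3cccc(OC)c3)nc12`, has not yet been measured. It stands to compound 3 as compound 2 stands to compound 1: methoxy in place of hydrogen on an aromatic carbon. The cores of compound 3 and compound 1 differ in more than one place, and that difference is not broken down here. The place of the methoxy is described in the same words for both pairs, so the change is the same one, applied to a different core.

Compound 4 is expected to give 2% in this assay, most likely between -6% and 10%. The expected step, no change at the digits printed from compound 3 to compound 4 (within the scatter), rests on the measured a number 10 percentage points lower from compound 1 to compound 2 (within the scatter) being within the scatter and on compound 3 already giving 2%, which leaves little room for a lower number.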

Compound 4, a percentage reported as inhibition, at one concentration (the size of the read-out at that concentration, not a potency): 3%
Compound 4: middle estimate off by 1 percentage points, on the low side; the range from low to high includes it.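

In this assay the new step reads a number 1 percentage points higher from compound 3 to compound 4 (within the scatter), and set beside the earlier step it shows no difference that can be counted on: the same change on two cores in this assay, a number 10 percentage points lower (within the scatter) from compound 1 to compound 2 and a number 1 percentage points higher (within the scatter) from compound 3 to compound 4, 11 percentage points apart, within the scatter of two such steps. Within these two pairs, then, methoxy in place of hydrogen on an aromatic carbon gives the same outcome on both cores: no step beyond the scatter in either direction. Within the data shown here, this does not show that the change is without effect in general or that it would carry over to other cores, since each core supplies only one pair, the read-out comes from one concentration and is not a potency, and two steps within the scatter could not reveal a modest dependence on the core.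

The compounds shown leave open whether an amine or a carboxylic acid in place of the methoxy group, or a longer chain in place of the ethoxy group of compound 3, would give a step beyond the scatter. They also leave open how the differences between the core of compound 1 and the core of compound 3 bear on the read-out, as no pair shown separates those differences one at a time.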